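Replacing the Terminal Ring on a Serotonin Receptor Ligand

A few compounds are considered here, and "the series" means these few. Any claim that something is new, unique, unknown or untested is made for them only; others in the source may bear on it.

Compound 1 `CCCCCN1CCC(NC(=O)c2cc(Cl)c(N)cc2OC)CC1` and compound 2 `COc1cc(N)c(Cl)cc1C(=O)NC1CCN(CCCCCN2CCCCC2)CC1` share the same core and differ only at the far end of a saturated chain. In an assay on HEK293 cells for displacement of a labelled ligand from 5-hydroxytryptamine receptor 4 (Homo sapiens), read by scintillation counting (a lower number here means a stronger inhibitor, a higher number a weaker inhibitor), compound 1 gives 100 nM, while compound 2 gives 10 nM. The step of a 10-fold lower number from compound 1 to compound 2 (1.00 log units; beyond the scatter) shows that attaching the ring helps, and compound 2 stands as the lower of the two numbers. Compound 3 `COc1cc(N)c(Cl)cc1C(=O)NC1CCN(CCCCCN2CCN(S(C)(=O)=O)CC2)CC1` carries the change (4-(methylsulfonyl)piperazin-1-yl in place of piperidin-1-yl on a saturated chain carbon, five bonds along the chain from an amine nitrogen in a ring). Among the measured compounds shown here, no measured step covers this exchange; the single known step concerns attaching the piperidinyl ring rather than altering it, so it bears on the question only loosely. Because compound 2 owes its standing to a 10-fold lower number from compound 1 to compound 2 (1.00 log units; beyond the scatter), part of that gain is expected to be given back when the ring is exchanged, and the estimated step is a 3.0-fold higher number from compound 2 to compound 3 (0.48 log units; beyond the scatter). Compound 3 is therefore expected at 30 nM, with a range from 8 nM to 150 nM.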

Compound 3, inhibition constant: 39.8 nM
Compound 3: middle estimate off by 1.3-fold (0.12 log units), on the low side; the measured number falls inside the stated range.
By their numbers in this assay, from the lowest: compound 2; then compound 3; then compound 1.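

In this assay the far end of the chain accepts more than one kind of ring, but the two rings are not equal: putting 4-(methylsulfonyl)piperazin-1-yl in place of piperidin-1-yl gives a 4.0-fold higher number from compound 2 to compound 3 (0.60 log units; beyond the scatter) for this exchange. The larger group still keeps part of the benefit of having a ring at this place, with a 2.5-fold lower number from compound 1 to compound 3 (0.40 log units; beyond the scatter) against the plain chain end. No supporting measurement accounts for the difference between the two rings.

Which part of the new group sets the size of this step remains open: a plain piperazin-1-yl or a morpholin-4-yl ring could separate the effect of the methylsulfonyl group from that of the ring atoms. From the compounds shown here alone, whether the same order of rings holds on a shorter or longer chain is also open.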